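A few compounds are considered here, and "the series" means these few. Any claim that something is new, unique, unknown or untested is made for them only; others in the source may bear on it.

Measured compounds:
compound 1 `Cc1ccc(N2CCN(C(=S)SCc3ccc(C(=O)Nc4ccccc4N)cc3)CC2)cc1` with 19.8%
compound 2 `Nc1ccccc1NC(=O)c1ccc(CSC(=S)N2CCN(c3ccccc3F)CC2)cc1` with 86.4%
compound 3 `Nc1ccccc1NC(=O)c1ccc(CSC(=S)N2CCN(c3ccncc3)CC2)cc1` with 87.1%

In a functional assay on MGC-803 cells (Homo sapiens) for antiproliferative activity, read by CCK-8 assay, with a stated time of 72 h, tested at 8 uM (on this read-out higher numbers stand for a stronger effect at the one concentration tested and lower numbers for a weaker effect), compound 3 gives the highest of the three numbers. Its nearest neighbour is compound 2, and the two sit within the scatter of each other, as a number 0.7 percentage points higher from compound 2 to compound 3 (within the scatter) shows, so neither can be called the stronger. Compound 1 lies far below both, with a number 66.6 percentage points higher from compound 1 to compound 2 (beyond the scatter) and a number 67.3 percentage points higher from compound 1 to compound 3 (beyond the scatter) marking large rises.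

Compound 4 `Nc1ccccc1NC(=O)c1ccc(CSC(=S)N2CCN(C3CCCCC3)CC2)cc1` has not yet been measured. It differs from compound 3 in one place: cyclohexyl in place of pyridin-4-yl on an amine nitrogen in a ring.

For the measured compounds named here, none of the measured steps involves a group of this kind; all three concern one six-membered aromatic ring exchanged for another. Going by the values given here, the steps that bear on the same position are a number 67.3 percentage points higher from compound 1 to compound 3 (beyond the scatter), which is large, and a number 0.7 percentage points higher from compound 2 to compound 3 (within the scatter), which is within the scatter. They show that what sits on this ring nitrogen can shift the read-out a great deal or hardly at all. The data give no way to tell which applies to a cyclohexyl group.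

The estimate for compound 4 is therefore wide, centred a little below compound 3, at 50% with a range from 10% to 90%, a step of a number 37.1 percentage points lower from compound 3 to compound 4 (beyond the scatter) expected in this assay.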

Compound 4, a percentage reported as inhibition, at one concentration (the size of the read-out at that concentration, not a potency): 75.3%
Estimate against measurement, compound 4: 25.3 percentage points below; the measured number falls inside the stated range.
By their numbers in this assay, from the lowest: compound 1; then compound 4; then compounds 2 and 3 (each within the scatter of the next).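

In this assay, the result shows that an aromatic ring is not required on this amine nitrogen for the read-out to stay high, since cyclohexyl, a six-membered non-aromatic ring of carbon only, gives a number 11.8 percentage points lower from compound 3 to compound 4 (beyond the scatter) and a number 11.1 percentage points lower from compound 2 to compound 4 (beyond the scatter), both modest steps. The same group gives a number 55.5 percentage points higher from compound 1 to compound 4 (beyond the scatter), a large step, so among the four groups only 4-methylphenyl gives a low number. Aromatic character alone therefore does not sort these compounds: the aromatic groups of compound 2 and compound 3 lie above the non-aromatic group of compound 4, while the aromatic group of compound 1 lies far below it.

The compounds shown leave open whether plain phenyl would stay with the high numbers or fall with 4-methylphenyl, and how an open chain such as butyl or a small group such as methyl would behave on this nitrogen. No evidence is available here to explain the differences among these groups.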